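A few compounds are considered here, and "the series" means these few. Any claim that something is new, unique, unknown or untested is made for them only; others in the source may bear on it.

In a functional assay (aorta) with Oryctolagus cuniculus as the target (on this read-out lower numbers stand for tighter binding and higher numbers for weaker binding), two compounds that share one core have been measured so far. Compound 1 `COc1cc(C(C)=O)ccc1OCCCN1CCC(C(c2ccc(F)cc2)c2ccc(F)cc2)CC1` gives 1.59 nM, and compound 2 `CCc1ccc(OCCCN2CCC(C(c3ccc(F)cc3)c3ccc(F)cc3)CC2)c(OC)c1` gives 2.51 nM. These two numbers lie within the usual scatter of each other, so compound 2 cannot be ranked against compound 1 on this evidence.

The next compound, compound 3 `COC(=O)c1ccc(OCCCN2CCC(C(c3ccc(F)cc3)c3ccc(F)cc3)CC2)c(OC)c1`, carries methoxycarbonyl in place of ethyl on an aromatic carbon, meta to a methoxy group and para to a large group: methoxycarbonyl in place of ethyl on an aromatic carbon. Within the data shown here, only one measured step bears on this change, the placing of ethyl where acetyl stood, and it amounts to a 1.6-fold higher number from compound 1 to compound 2 (0.20 log units; within the scatter). That is a single step, and methoxycarbonyl itself has not yet been measured in this series, so the evidence is thin. It gives no reason to expect a shift beyond the scatter in this assay, in either direction. The expected change is a 1.3-fold lower number from compound 2 to compound 3 (0.10 log units; within the scatter). Compound 3 is estimated at 2 nM, with an expected range from 0.7 nM to 6.5 nM.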

Compound 3, dissociation constant: 1.26 nM
Beside the measured number, compound 3's estimate is 1.6-fold (0.20 log units) above it; low and high end bracket the measured number.
By their numbers in this assay, from the lowest: compounds 3, 1 and 2 (each within the scatter of the next).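

In this assay, methoxycarbonyl and ethyl on this aromatic carbon cannot be told apart, with a 2.0-fold lower number from compound 2 to compound 3 (0.30 log units; within the scatter), even though the entering group brings more heavy atoms and two hydrogen-bond acceptors where ethyl has none. The smaller edit on the same side chain, methoxy in place of methyl on the carbonyl carbon, gives a 1.3-fold lower number from compound 1 to compound 3 (0.10 log units; within the scatter), so among these three compounds, no group at this position separates from the others, whether ethyl, acetyl or methoxycarbonyl. Nothing available here explains why these groups read alike.

From the compounds shown here alone, what a carboxylic acid, an amine or a longer chain on this aromatic carbon would give remains open, as does whether any group here can move the number in this assay beyond the scatter. The three compounds share everything outside this position, so they also leave open what a hydroxyl in place of the methoxy group on the same ring would do.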